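From 3-bromophenyl to 3-methoxyphenyl: an unmeasured step

The compounds below may be only part of what the source reports. "The series", "measured", "known", "first", "only" and "open" are said of these compounds alone.

Values in a functional assay on OVCAR-3 cells (Homo sapiens) for inhibition, read by MTT assay, with a stated time of 24 h; a higher number here means a weaker inhibitor, a lower number a stronger inhibitor:
- compound 1 `CC1(C)[C@H]2CC[C@]1(C)N(Cc1cn(-c3ccccc3C#N)nn1)C(=O)C2`: 110 nM
- compound 2 `Cc1ccccc1-n1cc(CN2C(=O)C[C@@H]3CC[C@@]2(C)C3(C)C)nn1`: 150 nM
- compound 3 `CC1(C)[C@H]2CC[C@]1(C)N(Cc1cn(-c3cccc(Br)c3)nn1)C(=O)C2`: 30 nM

Compound 3 holds the lowest number of the three. Compound 4 `COc1cccc(-n2cc(CN3C(=O)C[C@@H]4CC[C@@]3(C)C4(C)C)nn2)c1`, not yet measured, carries methoxy in place of bromo on an aromatic carbon, meta to a large group: methoxy in place of bromo on an aromatic carbon. Within the data shown here, no measured step makes this exact change. The nearest evidence comes from exchanges of the aryl group: a 3.7-fold lower number from compound 1 to compound 3 (0.56 log units; beyond the scatter) and a 5.0-fold lower number from compound 2 to compound 3 (0.70 log units; beyond the scatter), both modest, while a 1.4-fold higher number from compound 1 to compound 2 (0.13 log units; within the scatter) stays within the scatter. None of them compares methoxy with bromo, so confidence is limited. The expected change is a modest rise, a 2.0-fold higher number from compound 3 to compound 4 (0.30 log units; within the scatter). The estimated value for compound 4 is 60 nM, with an expected range from 22 nM to 160 nM.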

Compound 4, half-maximal inhibitory concentration: 280 nM
Compound 4: the middle estimate sits 4.7-fold (0.67 log units) below what was measured; the measured number lies above the stated range.
By their numbers in this assay, from the lowest: compound 3; then compounds 1, 2 and 4 (each within the scatter of the next, the first and the last beyond it).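

In this assay the exchange of bromo for methoxy at this place gives a 9.3-fold higher number from compound 3 to compound 4 (0.97 log units; beyond the scatter) and is the widest step among the four compounds. The low number of compound 3 thus does not carry over to 3-methoxyphenyl. Against the other aryl groups there is a 1.9-fold higher number from compound 2 to compound 4 (0.27 log units; within the scatter) and a 2.5-fold higher number from compound 1 to compound 4 (0.41 log units; beyond the scatter) and so no gain for 3-methoxyphenyl over 2-methylphenyl or 2-cyanophenyl.

Nothing available accounts for the gap between bromo and methoxy. As far as these compounds go, whether chloro, an amine or a carboxylic acid at this place would stand nearer compound 3 or compound 4 remains open.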